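The source may report more compounds than this note shows. Statements on the series, on what has been measured and on what is new or still open speak of the compounds shown alone.

Compound 1, `CC(=O)OC(C)n1cnc2c(Cl)nc(N)nc21`, was tested in a functional assay on CCRF-CEM cells (Homo sapiens) for inhibition; a lower number here means a stronger inhibitor, a higher number a weaker inhibitor. In this assay compound 1 gives > 500000 nM, which is a limit of the assay rather than a measured number. Compound 2, `CC(=O)OCCOn1cnc2c(Cl)nc(N)nc21`, shares the core of compound 1 and differs only in its side chain. In this assay compound 2 likewise gives > 500000 nM, again a limit and not a number. Compound 1 therefore stands exactly where every value shown stands: the limit of > 500000 nM in this assay, at which 2 of the 2 values shown sit. Compound 3, `CC(=O)OC(C)n1cnc2c(Cl)nc(I)nc21`, has not yet been measured in this assay. Its difference from compound 1 is iodo in place of amino on an aromatic carbon. For the measured compounds named here, no measured pair shows what this change does, and both values shown are limits, so neither a direction nor a size can be read from them. The step from compound 1 to compound 3 in this assay is expected to be a number no higher from compound 1 to compound 3 (the limit leaves the size open), that is, no movement beyond the usual scatter. Compound 3 is accordingly estimated to give 500000 nM in this assay, within a range of 100000 nM to 2000000 nM, and most probably the result will once more be only a limit.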

Compound 3, half-maximal inhibitory concentration: 15900 nM
For compound 3 the middle estimate is 31-fold (1.50 log units) above the measured one, outside the stated range (below it).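

In this assay, putting iodo in place of amino on the aromatic carbon between two ring nitrogen atoms gives an at least 31-fold lower number from compound 1 to compound 3 (1.49 log units; beyond the scatter). For the compounds shown here, this is the first sign that the group at this position can decide whether the compound registers as an inhibitor at all, and since the starting point is a limit rather than a number, the true size of the step stays open. Compound 3 is the only compound here to give a measured number, while the other two stay at a limit: the limit of > 500000 nM in this assay, at which 2 of the 3 values shown sit.

Going by these compounds alone, the single step cannot separate what losing the amino group does from what gaining the iodo group does, and a bromo group, a methoxy group or a plain hydrogen at the same carbon would help to tell these apart. Going by these compounds, it also remains open whether iodo has the same effect on the side chain of compound 2, and these values alone do not explain why the change matters.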